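This account rests on a few compounds, and the source may have more. Where it says the series, first, only, none or still open, it means among the compounds named here.

In a functional assay on DU-145 cells (Homo sapiens) for inhibition, read by trypan blue exclusion, with a stated time of 96 h (a lower number here means a stronger inhibitor of growth, a higher number a weaker inhibitor of growth), three compounds have been measured: compound 1 `O=C(/C(=C\c1ccc(Cl)cc1)SCc1ccc(F)cc1)c1ccc(Cl)cc1` gives 10000 nM; compound 2 `Cc1ccsc1/C=C(/SCc1ccc(F)cc1)C(=O)c1ccc(Cl)cc1` gives 50000 nM; compound 3 `O=C(/C(=C\c1ccc(Br)cc1)SCc1ccc(F)cc1)c1ccc(Cl)cc1` gives 9000 nM.

Compound 2 stands highest of the three numbers, seen in a 5.0-fold higher number from compound 1 to compound 2 (0.70 log units; beyond the scatter) and in a 5.6-fold lower number from compound 2 to compound 3 (0.74 log units; beyond the scatter), whereas compound 1 and compound 3 sit close together, with a 1.1-fold lower number from compound 1 to compound 3 (0.05 log units; within the scatter). Compound 4 `Cc1ccsc1/C=C(/SCc1ccccc1F)C(=O)c1ccc(Cl)cc1` differs from compound 2 by 2-fluorophenyl in place of 4-fluorophenyl on a saturated chain carbon bound to a sulfur. Within the data shown here, every measured step alters the group on the double-bonded chain carbon; none touches the saturated chain carbon bound to a sulfur, so no measured step bears on this change. The step from compound 2 to compound 4 is therefore expected to stay within the scatter, as a 1.1-fold lower number from compound 2 to compound 4 (0.05 log units; within the scatter). Compound 4 is estimated at 45000 nM, within a range of 15000 nM to 130000 nM.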

Compound 4, concentration for 50% growth inhibition: 50000 nM
Compound 4: the middle estimate sits 1.1-fold (0.05 log units) below what was measured, and the stated range covers the measured number.
By their numbers in this assay, from the lowest: compounds 3 and 1 (each within the scatter of the next); then compounds 2 and 4 (each within the scatter of the next).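

In this assay, putting 2-fluorophenyl in place of 4-fluorophenyl on a saturated chain carbon bound to a sulfur gave no change at the digits printed from compound 2 to compound 4 (within the scatter). Among these compounds, this is the only measured step at this place, and it shows that moving the fluorine leaves the reading where it was, at least with 3-methylthiophen-2-yl on the double-bonded chain carbon. No measurement shown here offers an explanation for this result.

Going by these compounds, whether the same swap reads alike with 4-chlorophenyl or 4-bromophenyl on that carbon remains open. So does the outcome of placing an amine or a carboxylic acid on the benzyl group, or of replacing that group with a longer chain.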